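A Methyl Group Added to Compound 2

A few compounds are considered here, and "the series" means these few. Any claim that something is new, unique, unknown or untested is made for them only; others in the source may bear on it.

Measured in a functional assay on HeLa cells (Homo sapiens) for inhibition, read by MTT assay, with a stated time of 72 h; a higher number here means a weaker inhibitor, a lower number a stronger inhibitor:
Compound 1 `COc1cc(NC(=O)/C=C/c2cccc(OCc3ccccc3)c2)cc(OC)c1OC`: 2200 nM
Compound 2 `C=C(Br)C(=O)Nc1cccc(/C=C/C(=O)Nc2ccccc2)c1`: 7300 nM
Compound 3 `C=C(Br)C(=O)Nc1cccc(/C=C/C(=O)Nc2cccc(F)c2)c1`: 1200 nM

Of these three, compound 2 has the highest number, 7300 nM, and is therefore the weakest inhibitor. Compound 4 `C=C(Br)C(=O)Nc1cccc(/C=C/C(=O)Nc2ccc(C)cc2)c1` has not yet been measured. It differs from compound 2 in one place, with methyl in place of hydrogen on an aromatic carbon.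

For the measured compounds named here, only one measured step bears on this change. Fluoro in place of hydrogen on an aromatic carbon gave a 6.1-fold lower number from compound 2 to compound 3 (0.78 log units; beyond the scatter). That step is modest but beyond the scatter. Going by the values given here, it brought in fluoro rather than methyl, however, and no measured step involves methyl, so it is only a loose guide. A smaller shift in the same direction is expected in this assay, although no shift beyond the scatter remains possible.

The expected change is a 1.9-fold lower number from compound 2 to compound 4 (0.28 log units; within the scatter).

The estimated value for compound 4 is 3800 nM, with an expected range from 1200 nM to 10000 nM.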

Compound 4, half-maximal inhibitory concentration: 1500 nM
The estimate for compound 4 lay 2.5-fold (0.40 log units) above the measured number, within the range that was stated.
By their numbers in this assay, from the lowest: compounds 3, 4 and 1 (each within the scatter of the next); then compound 2.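

In this assay, for the compounds shown here, methyl in place of hydrogen gives a 4.9-fold lower number from compound 2 to compound 4 (0.69 log units; beyond the scatter) and so shows that fluoro is not the only group on this ring that goes with a lower number than hydrogen. The other step, a 1.3-fold higher number from compound 3 to compound 4 (0.10 log units; within the scatter) within the scatter, shows that the 4-methylphenyl and 3-fluorophenyl groups cannot be told apart here, even though the two groups differ in kind and in where they sit on the ring. Nothing given here explains the effect of the methyl group.

On these data alone, it remains open whether an ethyl group or a longer chain at this place would keep the lower number, or whether an amine or a carboxylic acid would lose it. As far as these compounds go, it is also open whether methyl would give a similar step at another carbon of the same ring.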